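The source may report more compounds than this note shows. Statements on the series, on what has been measured and on what is new or still open speak of the compounds shown alone.

Compound 1 `CC(C)(C)[C@]1(c2ccccc2)OCC[C@H](CCNCc2ccccc2)O1` and compound 2 `CC(C)(C)[C@@]1(c2ccccc2)OCC[C@@H](CCNCc2ccccc2)O1` have the same atoms and bonds and differ only in how they are drawn in space. In an assay on brain for displacement of a labelled ligand from Sigma non-opioid intracellular receptor 1 (Cavia porcellus) (a lower number here means a stronger inhibitor, a higher number a weaker inhibitor), compound 1 gives 253 nM, and in this assay compound 2 gives 128 nM. Where compound 2 stands among these two numbers is set by the step of a 2.0-fold lower number from compound 1 to compound 2 (0.30 log units; within the scatter), which is within the scatter, so the two compounds cannot be told apart; this fits with the fact that compounds 1 and 2 differ only in the configuration as drawn. Compound 3 `c1ccc(CNCC[C@@H]2CCO[C@H](c3ccccc3)O2)cc1` arises from compound 2 by hydrogen in place of tert-butyl on a saturated ring carbon. Among the compounds with values here, no measured step bears on this change: the single step measured, a 2.0-fold lower number from compound 1 to compound 2 (0.30 log units; within the scatter), concerns configuration alone and says nothing about removing a group. The direction and size of the change in this assay therefore cannot be read from the two compounds measured, and a wide range is expected. Compound 3 is estimated at 400 nM, in a range from 100 nM to 2000 nM. The expected step of a 3.1-fold higher number from compound 2 to compound 3 (0.49 log units; beyond the scatter) leans toward a higher number, but only a little beyond the scatter.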

Compound 3, inhibition constant: 6 nM
Compound 3: the middle estimate sits 67-fold (1.82 log units) above what was measured, outside the stated range (below it).
By their numbers in this assay, from the lowest: compound 3; then compounds 2 and 1 (each within the scatter of the next).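

Swapping tert-butyl for hydrogen on the saturated ring carbon between two ring oxygen atoms is the first single change here that lies beyond the scatter: in this assay it gives a 21-fold lower number from compound 2 to compound 3 (1.33 log units; beyond the scatter). The mirror-image pair, compound 1 and compound 2, could not be told apart, so only this result shows that what sits on this carbon matters in this assay, with hydrogen giving the far stronger inhibitor of the two. Nothing given here explains why the number falls so far with this change.

The compounds shown set only tert-butyl against hydrogen at this carbon, so it stays open whether a methyl or an ethyl group would give a number nearer compound 2 or compound 3. As far as these compounds go, whether the mirror image of compound 3 would match it also stays open.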